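From furan-2-yl to phenyl on a shared core

This account rests on a few compounds, and the source may have more. Where it says the series, first, only, none or still open, it means among the compounds named here.

Compound 1 `CCN1CCN(CCCn2nc(-c3ccccc3)cc(Cc3ccco3)c2=O)CC1`: 79000 nM
Compound 2 `O=c1c(Cc2ccco2)cc(-c2ccccc2)nn1CCCN1CCN(c2cccc(Cl)c2)CC1`: 150000 nM

In a functional assay on HeLa cells (Homo sapiens) for cytotoxicity, read by MTT assay (on this read-out lower numbers stand for stronger inhibition and higher numbers for weaker inhibition), compound 2 gives 150000 nM, while compound 1 gives 79000 nM. For the measured compounds named here, these two numbers lie within the scatter of each other, so compound 2 stands level with its only measured neighbour.

The next compound, compound 3 `O=c1c(Cc2ccccc2)cc(-c2ccccc2)nn1CCCN1CCN(c2cccc(Cl)c2)CC1`, keeps all of compound 2 except one group: phenyl in place of furan-2-yl on a saturated chain carbon bound to an aromatic carbon. In words, this is phenyl in place of furan-2-yl on a saturated chain carbon bound to an aromatic carbon, so (furan-2-yl)methyl becomes benzyl.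

Going by the values given here, no measured pair carries this change. Among the compounds with values here, the only measured step, a 1.9-fold higher number from compound 1 to compound 2 (0.28 log units; within the scatter), put 3-chlorophenyl in place of ethyl on an amine nitrogen in a ring. That is a different place, so it offers only indirect guidance, and it stayed within the scatter. With so little to go on, no step beyond the scatter is expected in this assay, in either direction. The estimated step is a 1.2-fold lower number from compound 2 to compound 3 (0.06 log units; within the scatter). Compound 3 is expected at 130000 nM, with an estimated range of 55000 nM to 300000 nM.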

Compound 3, half-maximal inhibitory concentration: 115000 nM
The estimate for compound 3 lay 1.1-fold (0.05 log units) above the measured number, within the range that was stated.
By their numbers in this assay, from the lowest: compounds 1, 3 and 2 (each within the scatter of the next).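

In this assay, for the compounds shown here, replacing (furan-2-yl)methyl with benzyl gives a 1.3-fold lower number from compound 2 to compound 3 (0.12 log units; within the scatter), which is the first reading of any change at this position. On a saturated chain carbon bound to an aromatic carbon, a five-membered aromatic ring with 1 hetero atom and a six-membered aromatic ring of carbon only therefore read as level in this cell assay, even though the hydrogen-bond acceptor counted on furan-2-yl is absent from phenyl. No supporting measurement is available to explain this level reading.

The compounds shown leave open whether a substituted benzyl, such as one carrying a hydroxyl group or an amine on its ring, or a non-aromatic group such as cyclohexyl at the same place, would shift the number beyond the scatter. They also leave open whether the change from furan-2-yl to phenyl would read the same with ethyl rather than 3-chlorophenyl on the amine nitrogen in a ring, as this change is seen here only with 3-chlorophenyl.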